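Methyl in Place of Hydrogen on the Pendant Phenyl Ring

The source may report more compounds than this note shows. Statements on the series, on what has been measured and on what is new or still open speak of the compounds shown alone.

In an assay on isolated protein for inhibition of steroid 5-alpha-reductase (Rattus norvegicus) (on this read-out lower numbers stand for stronger inhibition and higher numbers for weaker inhibition), compound 2 `COc1ccccc1N1CCN(CCC(Oc2ccc(C(=O)Nc3ccccc3OCCCC(=O)O)cc2)c2ccccc2)CC1` gives 1000 nM, the highest number of the two measured values. The nearest measured compound, compound 1 `COc1ccccc1N1CCN(CCC(Oc2ccc(NC(=O)c3ccccc3OCCCC(=O)O)cc2)c2ccc(CC(C)C)cc2)CC1`, gives 96 nM in this assay, a markedly lower number, but compound 1 differs from compound 2 in more than one place, so that gap is not a single step and cannot be read as the effect of any one change.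

Compound 3 `COc1ccccc1N1CCN(CCC(Oc2ccc(C(=O)Nc3ccccc3OCCCC(=O)O)cc2)c2ccc(C)cc2)CC1` is compound 2 with one change: methyl in place of hydrogen on an aromatic carbon. Going by the values given here, no measured pair shows exactly this step, so the size of the step is open. Compound 1, which carries an alkyl group on the corresponding ring, gives the lower number, but its other differences from compound 2 leave that observation without a single cause.

Compound 3 is therefore expected to land somewhat below compound 2, with the step of a 2.0-fold lower number from compound 2 to compound 3 (0.30 log units; within the scatter) estimated as modest. The estimate for compound 3 is 500 nM, within a range from 150 nM to 1600 nM.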

Compound 3, half-maximal inhibitory concentration: 67 nM
Beside the measured number, compound 3's estimate is 7.5-fold (0.87 log units) above it; measured number below the stated range.
By their numbers in this assay, from the lowest: compounds 3 and 1 (each within the scatter of the next); then compound 2.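

Going from phenyl to 4-methylphenyl in this assay gives a 15-fold lower number from compound 2 to compound 3 (1.17 log units; beyond the scatter) and so shows that this one change, on an aromatic carbon para to a large group, is enough on its own to carry the number beyond the scatter. Going by these compounds alone, a single added carbon therefore counts for much at this place on the pendant ring, which the earlier compounds could not show, as the only gap they offered spanned more than one change. Nothing measured here says why one methyl makes a step of this size.

Still open, from the compounds shown here alone, is whether methyl is special at this place or whether another group, such as a chlorine atom, a methoxy group or a longer chain such as ethyl, would give a step of similar size. Within the data shown here, also open is whether methyl on another carbon of this ring would do the same, and whether the step would carry over to a different core, such as the one in compound 1.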